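The compounds below may be only part of what the source reports. "The series", "measured", "known", "first", "only" and "open" are said of these compounds alone.

Measured so far in an in vitro functional assay on Sf9 cells for antagonist activity at histamine H2 receptor (Homo sapiens); on this read-out lower numbers stand for lower potency and higher numbers for higher potency (the scale is a negative logarithm):

Compound 1, `N#C/N=C(\NCCCc1ccccc1)NCCCc1c[nH]cn1`: 5.25
Compound 2, `N#C/N=C(\NCCCCc1ccccc1)NCCCc1c[nH]cn1`: 5.03

Compound 2 stands lowest of the two numbers in this assay, with compound 1 its nearest neighbour; the step from compound 1 to compound 2, a number 0.22 log units lower from compound 1 to compound 2 (within the scatter), lies within the scatter of repeated measurements, so the two compounds cannot be told apart on potency.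

Compound 3, `N#C/N=C(/NCCCc1c[nH]cn1)NCCSc1ccccc1`, is still to be measured in this assay. It differs from compound 2 in one place: phenylsulfanyl in place of phenethyl on a saturated chain carbon, two bonds along the chain from an amine nitrogen. For the measured compounds named here, the only measured step that bears on this change is the lengthening of the phenyl-bearing chain from compound 1 to compound 2, which gave a number 0.22 log units lower from compound 1 to compound 2 (within the scatter). Compound 3 shortens that chain again by one link and places a sulfur in it; nothing measured speaks to the sulfur itself. Given that the one related step stayed within the scatter, no change beyond the scatter is expected for compound 3 in this assay; a step of a number 0.17 log units higher from compound 2 to compound 3 (within the scatter) from compound 2 is estimated. Compound 3 is therefore expected to give about 5.2 in this assay, in a range from 4.7 to 5.7.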

Compound 3, negative logarithm of the antagonist equilibrium constant: < 5
Compound 3 was reported as a limit (the forecaster's own chance of this, stated with the estimate: 5%); middle value at least 0.20 log units away from the limit.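

In this assay compound 3 is reported as a limit, < 5, and not as a number. Phenylsulfanyl in place of phenethyl on a saturated chain carbon, two bonds along the chain from an amine nitrogen, gives a number at least 0.03 log units lower from compound 2 to compound 3 (that floor lies within the scatter), and phenylsulfanyl in place of benzyl at the same place gives a number at least 0.25 log units lower from compound 1 to compound 3 (that floor lies within the scatter); neither step establishes a real loss of potency, and neither excludes a larger one. Compound 1 and compound 2, both without sulfur, return numbers, whereas phenylsulfanyl at this place gives the first result in the series without one, and the true size of the change stays unknown because the result is a limit: the limit of < 5 in this assay, at which 1 of the 3 values shown sits.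

The compounds shown leave open whether any loss belongs to the sulfur itself or to the way the phenyl ring is attached to the chain. An oxygen ether in place of the sulfur, or a longer chain that still carries the sulfur, would help to separate these two readings in this assay.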